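Swapping a bromo-cyano aryl for a nitro aryl

A few compounds are considered here, and "the series" means these few. Any claim that something is new, unique, unknown or untested is made for them only; others in the source may bear on it.

Three hydrazone derivatives built on a shared core have been tested in an ADME assay on MT4 cells (Homo sapiens) for cytotoxicity, read by MTT assay, with a stated time of 4 days; on this read-out higher numbers stand for lower toxicity in this test and lower numbers for higher toxicity in this test. Compound 1, `C/C(=N\NC(=O)COc1cccc2ccccc12)c1ccc(C#N)cc1Br`, gives 12.1 ug/mL in this assay. Compound 2, `COc1ccc(/C=N/NC(=O)COc2cccc3ccccc23)cc1O`, gives 7.05 ug/mL, a value within the scatter of compound 1, so the two cannot be told apart. Compound 3, `O=C(COc1cccc2ccccc12)N/N=C/c1ccc([N+](=O)[O-])cc1`, gives 87.9 ug/mL, a much higher number that lies beyond the scatter and marks compound 3 as less toxic than compound 1 in this test. Compound 1 therefore holds the second highest of the three numbers, close to compound 2 and well below compound 3.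

Compound 4, `C/C(=N\NC(=O)COc1cccc2ccccc12)c1ccc([N+](=O)[O-])cc1`, has not yet been measured. It differs from compound 1 in one place: 4-nitrophenyl in place of 2-bromo-4-cyanophenyl on a carbon with a double bond to nitrogen. The 4-nitrophenyl that enters is the same group that compound 3 carries, and compound 3 shows the highest number of the three. On that basis the step from compound 1 to compound 4 is expected to be upward, toward lower toxicity, and estimated as a 4.1-fold higher number from compound 1 to compound 4 (0.62 log units; beyond the scatter), beyond the scatter. Compound 4 is therefore expected to give about 50 ug/mL in this assay, with a range from 15 ug/mL to 120 ug/mL.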

Compound 4, half-maximal cytotoxic concentration: 89.3 ug/mL
The estimate for compound 4 lay 1.8-fold (0.25 log units) below the measured number; measured number inside the range.
By their numbers in this assay, from the lowest: compounds 2 and 1 (each within the scatter of the next); then compounds 3 and 4 (each within the scatter of the next).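

In this assay, among the compounds shown here, putting 4-nitrophenyl in place of 2-bromo-4-cyanophenyl on a carbon with a double bond to nitrogen gives a 7.4-fold higher number from compound 1 to compound 4 (0.87 log units; beyond the scatter) and is the first step here between two compounds that differ in one place, so the aryl group at this position can by itself move the number beyond the scatter. The two compounds carrying 4-nitrophenyl agree: compound 3 gives 87.9 ug/mL and compound 4 gives 89.3 ug/mL in this test, values within the scatter of each other even though compound 3 lacks the saturated chain carbon found in compound 4. No measurement available here explains why this exchange is linked to lower toxicity in this test.

The exchange removes the bromine and the nitrile and brings in the nitro group all at once, so the compounds shown cannot reveal which of these changes accounts for the step, and a phenyl carrying only the bromine or only the nitrile would be needed to separate them. On these data alone, how this position would read with an amine or a carboxylic acid on the phenyl in place of the nitro group also remains open.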